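Aryl Variation on the Shared Core: Toward Compound 3

The compounds below may be only part of what the source reports. "The series", "measured", "known", "first", "only" and "open" are said of these compounds alone.

For the measured compounds named here, compound 2 `COc1ccc(S(=O)(=O)N2CCc3cccc(-c4cccnc4)c32)cc1` holds the highest of the two numbers so far: in a functional assay on NCI-H460 cells (Homo sapiens) for inhibition, with a stated time of 72 h (on this read-out higher numbers stand for weaker inhibition and lower numbers for stronger inhibition), compound 2 gives 89.6 nM, whereas compound 1 `COc1ccc(S(=O)(=O)N2CCc3cccc(-c4ccc([N+](=O)[O-])cc4)c32)cc1` gives 53.1 nM, the two within the scatter of each other. Going by the values given here, the single step that bears on the next change is a 1.7-fold higher number from compound 1 to compound 2 (0.23 log units; within the scatter). Compound 3 `COc1ccc(S(=O)(=O)N2CCc3cccc(-c4ccc(F)cc4)c32)cc1` differs from compound 2 by 4-fluorophenyl in place of pyridin-3-yl on an aromatic carbon. As the earlier aryl swap at this carbon stayed within the scatter, no step beyond it is expected here. For compound 3 the expected step is a 1.5-fold lower number from compound 2 to compound 3 (0.17 log units; within the scatter). Compound 3 is estimated at 60 nM, with a range from 25 nM to 150 nM.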

Compound 3, half-maximal inhibitory concentration: 95.5 nM
Compound 3: the middle estimate sits 1.6-fold (0.20 log units) below what was measured; the range from low to high includes it.
By their numbers in this assay, from the lowest: compounds 1, 2 and 3 (each within the scatter of the next).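

In this assay, 4-fluorophenyl in place of pyridin-3-yl gives a 1.1-fold higher number from compound 2 to compound 3 (0.03 log units; within the scatter) and fluoro in place of nitro gives a 1.8-fold higher number from compound 1 to compound 3 (0.25 log units; within the scatter) on the same aromatic carbon. A ring of carbon only and a ring with a hetero atom therefore cannot be told apart at this position, and neither can the two substituted phenyl rings. Nothing measured here accounts for these small steps.

Still open, from the compounds shown here alone, is whether a group other than a six-membered aromatic ring, such as an amine, a carboxylic acid or a longer alkyl chain, would move the read-out beyond the scatter at this carbon.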